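The source may report more compounds than this note shows. Statements on the series, on what has been measured and on what is new or still open speak of the compounds shown alone.

Within the data shown here, compound 3 `O=C(O)CCn1c(=O)oc2cc(OCC3CC3)c(Cl)cc21` is the one compound of the three whose result in a physicochemical assay for permeability, using PAMPA (on this read-out lower numbers stand for lower permeability and higher numbers for higher permeability), is an actual number: in this assay compound 3 gives 19 nm/s. For compound 1 `CCOc1cc2oc(=O)n(CCC(=O)O)c2cc1Cl` the result in this assay is only a limit, < 10 nm/s. For compound 2 `CCc1cc2oc(=O)n(CCC(=O)O)c2cc1Cl` the result in this assay is likewise a limit, < 10 nm/s. Among the measured compounds shown here, compounds 1 and 2 thus both sit at the limit of < 10 nm/s in this assay, at which 2 of the 3 values shown sit, and compound 3 stands alone as the single readable value.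

Compound 4 `C[C@@H](Oc1cc2oc(=O)n(CCC(=O)O)c2cc1Cl)c1ncco1` differs from compound 3 in one place: a group of 7 heavy atoms (5 carbon, 1 nitrogen, 1 oxygen; one five-membered aromatic ring with 2 hetero atoms) in place of a group of 4 heavy atoms (4 carbon; one three-membered non-aromatic ring of carbon only), on an oxygen on an aromatic ring. Of the measured steps, the one that touches this position is an at least 1.9-fold higher number from compound 1 to compound 3 (0.27 log units; that floor lies within the scatter), which changed the group on the same oxygen; the step of an at least 1.9-fold higher number from compound 2 to compound 3 (0.27 log units; that floor lies within the scatter) also arrives at compound 3 but replaces a different kind of substituent. Both steps carry a floor that lies within the scatter, and neither covers a group holding hetero atoms on that oxygen. On that basis the step of a 1.9-fold lower number from compound 3 to compound 4 (0.28 log units; within the scatter) is expected to run downward, back toward the limit at which compounds 1 and 2 sit. Compound 4 is therefore estimated at 10 nm/s, with a range from 3 nm/s to 25 nm/s.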

Compound 4, apparent permeability: < 3 nm/s
Compound 4: only a limit was reported (the forecaster's own chance of this, stated with the estimate: 50%); middle value at least 3.3-fold (0.52 log units) away from the limit.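

In this assay, a change on the oxygen on an aromatic ring now gives a step that is printed as beyond the scatter: an at least 6.3-fold lower number from compound 3 to compound 4 (0.80 log units; beyond the scatter). The earlier steps arriving at compound 3 offered only floors within the scatter, so this is the first clear separation among the compounds shown, and it comes with a group holding a five-membered aromatic ring with 2 hetero atoms and 1 defined stereocentre in place of cyclopropylmethyl. Compound 4 gives a limit and not a number, so the step has a minimum size only, and compound 4 stands alone at that limit: the limit of < 3 nm/s in this assay, at which 1 of the 4 values shown sits.

The steps from compound 1 and from compound 2 to compound 4 cannot be read, with limits at both ends, so the order among these three compounds stays open. Also open, as far as these compounds go, is whether the 1,3-oxazol-2-yl ring or the chain carbon bearing it, with its defined stereocentre, accounts for the step, and how an amine or a longer chain on that oxygen would read in this assay.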